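The source may hold more compounds than are shown below. What is called first, only, known or untested is meant among the compounds shown, and "the series" means these compounds.

Compound 1 `CC/N=C(/N)Nc1nc(-c2ccc(OC)cc2)c(-c2ccc(OC)cc2)s1`: in a functional assay with Oryctolagus cuniculus as the target (a higher number here means a weaker inhibitor, a lower number a stronger inhibitor), compound 1 gives > 100 nM, which is a limit of the assay and not a number.
Compound 2 `COc1ccc(-c2nc(CNC(=O)CSC)sc2-c2ccc(OC)cc2)cc1`: in this assay compound 2 gives < 100 nM, again a limit.
Compound 3 `COc1ccc(-c2nc(C(N)=O)sc2-c2ccc(OC)cc2)cc1`: in this assay compound 3 gives > 1000 nM, also a limit.

Compound 3 therefore stands at the weak end of what is shown, with no number of its own, only the limit at which it sits (the limit of > 1000 nM in this assay, at which 1 of the 3 values shown sits). The unmeasured compound 4 `COc1ccc(-c2nc(/C=C/C(=O)O)sc2-c2ccc(OC)cc2)cc1` differs from it in one place: 2-carboxyethenyl in place of carbamoyl on an aromatic carbon.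

Among the measured compounds shown here, only one measured step touches the same carbamoyl: an at least 10-fold higher number from compound 2 to compound 3 (1.00 log units; beyond the scatter), at least modest and beyond the scatter, and read the other way round it shows that a longer group on that carbon went with a lower number. The two steps from compound 1, a number no higher from compound 1 to compound 2 (the limit leaves the size open) and a step that the two limits leave unreadable from compound 1 to compound 3, leave their size open. A lengthening of the carbamoyl into 2-carboxyethenyl is thus expected to pull the number down somewhat, yet the step expected, a step that the limit leaves unreadable from compound 3 to compound 4, is read as small, since compound 3 itself offers no number to move from. Compound 4 is expected to give about 1500 nM, within a range from 300 nM to 8000 nM.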

Compound 4, half-maximal inhibitory concentration: > 100 nM
Compound 4: only a limit was reported; the forecaster's own chance of this, stated with the estimate: 50%; the middle value does not contradict the limit.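

In this assay compound 4 gives > 100 nM, which is a limit of the assay and not a number. The comparison with the longer group of compound 2 shows a number no lower from compound 2 to compound 4 (the limit leaves the size open), so lengthening the carbamoyl into 2-carboxyethenyl at this position does not by itself bring compound 4 to the side of the limit on which compound 2 sits. The steps to compound 4 from compound 3 and from compound 1 cannot be read, so the data do not tell whether 2-carboxyethenyl is any better or worse than carbamoyl here.

The compounds shown leave open which part of the side chain of compound 2 goes with its low limit. A plain aminomethyl group or a saturated chain ending in a carboxylic acid on the same carbon would bear on this.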